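The source may hold more compounds than are shown below. What is called first, only, known or untested is meant among the compounds shown, and "the series" means these compounds.

Compound 3 `Oc1cccc(-c2cc(-c3cccnc3)cc(-c3cccc(O)c3)n2)c1` carries a pyridin-3-yl group and two 3-hydroxyphenyl groups on the shared core. In a functional assay on HeLa cells (Homo sapiens) for cytotoxicity, read by CCK-8 assay (a higher number here means a weaker inhibitor, a lower number a stronger inhibitor), compound 3 gives only a limit, > 50000 nM, and not a number. That is the limit of the assay itself (the limit of > 50000 nM in this assay, at which 1 of the 3 values shown sits). Compound 4 `Oc1ccc(-c2cc(-c3cccnc3)cc(-c3cccc(O)c3)n2)cc1` has not yet been measured; it differs from compound 3 in one place: 4-hydroxyphenyl in place of 3-hydroxyphenyl on an aromatic carbon. Within the data shown here, no measured step swaps these two groups. Among the measured compounds shown here, the single measured step, a 1.2-fold higher number from compound 1 to compound 2 (0.10 log units; within the scatter), concerns a different position and changed little. Compound 1 `Oc1ccc(-c2cc(-c3cccs3)cc(-c3cccc(O)c3)n2)cc1` and compound 2 `Oc1ccc(-c2cc(-c3ccco3)cc(-c3cccc(O)c3)n2)cc1` carry the same pairing of a 4-hydroxyphenyl and a 3-hydroxyphenyl group as compound 4, but with a thiophen-2-yl or a furan-2-yl group where compound 4 has pyridin-3-yl; in this assay compound 1 gives 4140 nM and compound 2 gives 5170 nM. For the measured compounds named here, those two compounds are the only guide. The step from compound 3 to compound 4 is therefore expected to be an at least 2.5-fold lower number from compound 3 to compound 4 (0.39 log units; beyond the scatter), though compound 4 may also end at a limit. For compound 4 the expected value in this assay is 20000 nM, between 6000 nM and 60000 nM.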

Compound 4, half-maximal inhibitory concentration: > 50000 nM
Compound 4: a limit, no number; the forecaster's own chance of this, stated with the estimate: 40%; at least 2.5-fold (0.39 log units) between middle value and limit.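

In this assay, the step between compound 3 and compound 4 cannot be read, because both stand at a limit and not at a number: the limit of > 50000 nM in this assay, at which 2 of the 4 values shown sit. Among these compounds, the clearer news comes from the group that differs from the earlier compounds: with the same 4-hydroxyphenyl and 3-hydroxyphenyl pairing, pyridin-3-yl in place of furan-2-yl gives an at least 9.6-fold higher number from compound 2 to compound 4 (0.98 log units; beyond the scatter), and pyridin-3-yl in place of thiophen-2-yl gives an at least 12-fold higher number from compound 1 to compound 4 (1.08 log units; beyond the scatter). So the position where furan-2-yl and thiophen-2-yl gave values within the scatter of each other does respond to the group it carries, and pyridin-3-yl weakens the effect.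

Going by these compounds, whether 4-hydroxyphenyl or 3-hydroxyphenyl is the better partner remains open, since neither compound with pyridin-3-yl gives a number. Also open, on these data alone, is what a plain phenyl ring or a pyridin-4-yl group would give at this position.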